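A Bromine-Bearing Group Replaces a Chlorine-Bearing One

The source may report more compounds than this note shows. Statements on the series, on what has been measured and on what is new or still open speak of the compounds shown alone.

Compound 1 `O=C1O/C(=C\Cn2cnc3c(F)nc(F)c(Cl)c32)C(OCc2ccccc2)=C1OCc1ccccc1`: > 100000 nM (a limit)
Compound 2 `O=C1O/C(=C\Cn2cnc3ccnc(Cl)c32)C(OCc2ccccc2)=C1OCc1ccccc1`: > 100000 nM (a limit)

In a functional assay on HeLa cells (Homo sapiens) for antiproliferative activity, read by MTT assay, with a stated time of 72 h (on this read-out higher numbers stand for weaker inhibition and lower numbers for stronger inhibition), compound 2 gives > 100000 nM, which is a limit and not a number. Compound 1 gives > 100000 nM, which is also a limit. Both compounds therefore sit at the limit of > 100000 nM in this assay, at which 2 of the 2 values shown sit. Among the compounds with values here, the one measured step is a step that the two limits leave unreadable from compound 1 to compound 2, so it offers no size to carry forward.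

Compound 3 `O=C1O/C(=C\Cn2cnc3ncc(Br)c-3c2)C(OCc2ccccc2)=C1OCc1ccccc1` differs from compound 2 by a new change: a group of 10 heavy atoms (6 carbon, 3 nitrogen, 1 bromine; one five-membered aromatic ring with 1 hetero atom, one six-membered aromatic ring with 2 hetero atoms) in place of a group of 10 heavy atoms (6 carbon, 3 nitrogen, 1 chlorine; one five-membered aromatic ring with 2 hetero atoms, one six-membered aromatic ring with 1 hetero atom), on a saturated chain carbon bound to a double-bonded chain carbon. Bromine replaces chlorine, and the ring with two hetero atoms is now the six-membered one. Within the data shown here, no measured step covers such a swap, so the only guide is the limit reached by compound 2 at > 100000 nM. The expected a number no higher from compound 2 to compound 3 (the limit leaves the size open) is no shift beyond the scatter, in either direction. The estimate for compound 3 is 100000 nM, with an expected range of 30000 nM to 300000 nM.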

Compound 3, half-maximal inhibitory concentration: 17000 nM
For compound 3 the middle estimate is 5.9-fold (0.77 log units) above the measured one, and the stated range ends above it.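

The group on the saturated chain carbon can move this series off its limit: in this assay the new group gives an at least 5.8-fold lower number from compound 2 to compound 3 (0.76 log units; beyond the scatter), and set against the fluorine-bearing group it gives an at least 5.8-fold lower number from compound 1 to compound 3 (0.76 log units; beyond the scatter). Within the data shown here, compound 3 is therefore the first compound here with a real number rather than a limit, and both steps are lower bounds on the true size. The step from compound 1 to compound 2 cannot be read, and those two compounds show only this: the limit of > 100000 nM in this assay, at which 2 of the 3 values shown sit.

Bromine and the rearranged ring system enter together, so the compounds shown cannot tell which of the two carries the step. Also open, as far as these compounds go, is what would follow with chlorine on the ring system of compound 3, or with an amine or a nitrile in place of its bromine.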